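Replacing a thiophene arm with a prenyl chain on the amine

The source may report more compounds than this note shows. Statements on the series, on what has been measured and on what is new or still open speak of the compounds shown alone.

Of the compounds shown here, three sharing one core have been tested. In an assay on CHO cells for displacement of a labelled ligand from 5-hydroxytryptamine receptor 1B (Homo sapiens) (a higher number here means a weaker inhibitor, a lower number a stronger inhibitor), compound 1 `C[C@@H](NCC1CCN(CCCc2c[nH]c3ccc(-n4cnnc4)cc23)CC1)c1ccccc1` gives 14 nM. Compound 2 `c1ccc(CNCC2CCN(CCCc3c[nH]c4ccc(-n5cnnc5)cc34)CC2)cc1` gives 28 nM in this assay, and compound 3 `CN(Cc1ccsc1)C1CCN(CCCc2c[nH]c3ccc(-n4cnnc4)cc23)CC1` gives 35 nM. Compound 3 thus shows the highest of the three numbers; its step from compound 1 is a 2.5-fold higher number from compound 1 to compound 3 (0.40 log units; beyond the scatter), while the step from compound 2 is a 1.3-fold higher number from compound 2 to compound 3 (0.10 log units; within the scatter). Compound 4 `CC(C)=CCN(C)C1CCN(CCCc2c[nH]c3ccc(-n4cnnc4)cc23)CC1` differs from compound 3 in one place: 2-methylprop-1-en-1-yl in place of thiophen-3-yl on a saturated chain carbon bound to an amine nitrogen. Among the compounds with values here, none of the measured steps swaps an aromatic ring for an open chain at this position; the nearest comparisons are the changes around the amine, namely a 2.0-fold higher number from compound 1 to compound 2 (0.30 log units; within the scatter) and a 1.3-fold higher number from compound 2 to compound 3 (0.10 log units; within the scatter), both small. Within the data shown here, with no direct precedent, a modest weakening is expected for compound 4, on the order of a 2.0-fold higher number from compound 3 to compound 4 (0.30 log units; within the scatter). Compound 4 is therefore estimated at 70 nM in this assay, with a plausible range from 25 nM to 200 nM.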

Compound 4, half-maximal inhibitory concentration: 41 nM
Compound 4: middle estimate off by 1.7-fold (0.23 log units), on the high side; low and high end bracket the measured number.
By their numbers in this assay, from the lowest: compounds 1, 2, 3 and 4 (each within the scatter of the next, the first and the last beyond it).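

In this assay, the step at this position (a 1.2-fold higher number from compound 3 to compound 4 (0.07 log units; within the scatter)) shows that an open chain with one double bond, 2-methylprop-1-en-1-yl, can stand in for the aromatic thiophen-3-yl on this saturated chain carbon with no change beyond the scatter. The wider change on the saturated ring carbon reads the same way against one neighbour but not the other: the step to compound 4 is within the scatter from compound 2 (a 1.5-fold higher number from compound 2 to compound 4 (0.17 log units; within the scatter)) and beyond it, though modest, from compound 1 (a 2.9-fold higher number from compound 1 to compound 4 (0.47 log units; beyond the scatter)). So, among these compounds, the thiophene ring is not needed to keep the number in this range. No measured evidence accounts for this tolerance. On these data alone, it remains open whether a saturated 3-methylbutyl chain, or an arm ending in a carboxylic acid or a hydroxyl group, would be tolerated equally at this position.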